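Bromotriazole Replaces Methyltriazole on a Shared Oxazolidinone Scaffold

This account rests on a few compounds, and the source may have more. Where it says the series, first, only, none or still open, it means among the compounds named here.

Of the compounds shown here, three built on one core have been measured in an assay for binding affinity to Amine oxidase [flavin-containing] A (Homo sapiens); a higher number here means a weaker inhibitor, a lower number a stronger inhibitor. Compound 1 `CC(C)(C)OC(=O)c1cn(C[C@H]2CN(c3ccc(C4=CCS(=O)(=O)CC4)c(F)c3)C(=O)O2)nn1` gives 3500 nM. Compound 2 `O=C1O[C@@H](Cn2cc(Cl)nn2)CN1c1ccc(C2=CCS(=O)(=O)CC2)c(F)c1` gives 3000 nM, and compound 3 `Cc1cnnn1C[C@H]1CN(c2ccc(C3=CCS(=O)(=O)CC3)c(F)c2)C(=O)O1` gives 4500 nM. Of the three figures, that of compound 3 is the highest, but it is not separated from the others beyond the scatter: a 1.5-fold higher number from compound 2 to compound 3 (0.18 log units; within the scatter), and the gap between compound 3 and compound 1 is of the same kind. The other single change, a 1.2-fold lower number from compound 1 to compound 2 (0.07 log units; within the scatter), likewise stays inside the scatter. Compound 4 `O=C1O[C@@H](Cn2cc(Br)nn2)CN1c1ccc(C2=CCS(=O)(=O)CC2)c(F)c1` has not yet been measured. It differs from compound 3 in one place: 4-bromo-1H-1,2,3-triazol-1-yl in place of 5-methyl-1H-1,2,3-triazol-1-yl on a saturated chain carbon bound to a saturated ring carbon. For the measured compounds named here, the step that bears most directly on this is the one between compound 2 and compound 3, which exchanged a chloro-bearing triazole for a methyl-bearing one and moved the number only within the scatter; compound 4 carries a bromo-bearing triazole of the same substitution pattern as compound 2. Since the measured steps on this core have all stayed within the scatter, no step beyond the scatter is expected here either, with the number expected to sit nearer to that of compound 2, a 1.5-fold lower number from compound 3 to compound 4 (0.18 log units; within the scatter). Compound 4 is therefore estimated at 3000 nM, within a range from 1500 nM to 6000 nM.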

Compound 4, inhibition constant: 16000 nM
Estimate against measurement, compound 4: 5.3-fold (0.73 log units) below; the whole stated range lies below it.
By their numbers in this assay, from the lowest: compounds 2, 1 and 3 (each within the scatter of the next); then compound 4.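

In this assay, the tert-butoxycarbonyl, chloro and methyl variants on the triazole had shown no step beyond the scatter, so this part of the molecule had seemed insensitive to change; the bromo group breaks that picture, with a 3.6-fold higher number from compound 3 to compound 4 (0.55 log units; beyond the scatter) and a 4.6-fold higher number from compound 1 to compound 4 (0.66 log units; beyond the scatter). The largest of the new steps comes from the exchange of one halogen for another on the same aromatic carbon, a 5.3-fold higher number from compound 2 to compound 4 (0.73 log units; beyond the scatter), which shows that chloro and bromo are not interchangeable on this core in this measurement. The 5-methyl-1H-1,2,3-triazol-1-yl and 4-bromo-1H-1,2,3-triazol-1-yl groups have equal counts of heavy atoms and hydrogen-bond acceptors, so those counts do not separate compound 3 from compound 4, and no supporting data are available to explain the rise.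

The compounds shown leave open whether this rise is particular to bromo or would also appear with iodo or a nitrile on the same triazole carbon. They also leave open whether the chloro-to-bromo step would keep its size on a core other than this one.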